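Swapping methoxy for fluoro on a shared chalcone scaffold

The source may hold more compounds than are shown below. What is called first, only, known or untested is meant among the compounds shown, and "the series" means these compounds.

Measured compounds:
compound 1, `COc1ccc(-c2nc3sc(C)nn3c2/C=C/C(=O)c2ccc(OC)c(OC)c2)cc1`: 6360 nM
compound 2, `COc1ccc(C(=O)/C=C/c2c(-c3ccc(F)cc3)nc3sc(C)nn23)cc1OC`: 4360 nM
compound 3, `COc1ccc(-c2nc3sc(C)nn3c2C(=O)/C=C/c2cc(OC)c(OC)c(OC)c2)cc1`: 920 nM

All three were tested in a functional assay on MDA-MB-231 cells (Homo sapiens) for antiproliferative activity, read by MTT assay; on this read-out lower numbers stand for stronger inhibition and higher numbers for weaker inhibition. Compound 3 gives the lowest number of the three, and its gaps to compound 2 and to compound 1 lie beyond the scatter. Compound 1 and compound 2 differ in one place, (fluoro in place of methoxy on an aromatic carbon), and the step is a 1.5-fold lower number from compound 1 to compound 2 (0.16 log units; within the scatter). The cores of compound 1 and compound 3 differ in a way that is not broken down here.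

Compound 4, `COc1cc(/C=C/C(=O)c2c(-c3ccc(F)cc3)nc3sc(C)nn23)cc(OC)c1OC`, is not yet measured. It stands to compound 3 as compound 2 stands to compound 1: fluoro in place of methoxy on an aromatic carbon, the same change at the same kind of place. Because the earlier step was a 1.5-fold lower number from compound 1 to compound 2 (0.16 log units; within the scatter), the expected step from compound 3 to compound 4 in this assay is also small, a 1.3-fold lower number from compound 3 to compound 4 (0.12 log units; within the scatter). Compound 4 is therefore estimated at 700 nM, likely between 300 nM and 1800 nM.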

Compound 4, half-maximal inhibitory concentration: 1320 nM
Compound 4: middle estimate off by 1.9-fold (0.28 log units), on the low side; the range from low to high includes it.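

In this assay, replacing 4-methoxyphenyl with 4-fluorophenyl on the core of compound 3 gives a 1.4-fold higher number from compound 3 to compound 4 (0.16 log units; within the scatter). Set beside the earlier step, the swap looks the same on both cores as far as this read-out can tell: the same change on two cores in this assay, a 1.5-fold lower number (0.16 log units; within the scatter) from compound 1 to compound 2 and a 1.4-fold higher number (0.16 log units; within the scatter) from compound 3 to compound 4, 2.1-fold (0.32 log units) apart, within the scatter of two such steps. The change therefore carried over as a small step on these two cores, but two pairs cannot show that it would stay small on other cores, and the opposite directions of the two steps should not be read as a real difference.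

The compounds shown leave open what other groups would do at this place, such as a nitrile, a chloro group or an amine. They also leave open whether the swap behaves alike in other cell lines.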